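This account rests on a few compounds, and the source may have more. Where it says the series, first, only, none or still open, it means among the compounds named here.

Measured compounds:
Compound 1, `CC(C)(C)OC(=O)CCC[N+]1(C)CCc2c(sc(NC(=O)Nc3ccc(Cl)cc3)c2C(N)=O)C1`, gives 250 nM in a functional assay (strain AB) with Danio rerio as the target, read by microscopy, with a stated time of 1 h; on this read-out higher numbers stand for an effect only at larger amounts of compound and lower numbers for an effect already at smaller amounts.
Compound 2, `CCN1CCc2c(sc(NC(=O)Nc3cccc(C#N)c3)c2C(N)=O)C1`, gives 10300 nM in this assay.

Among the measured compounds shown here, on these numbers compound 1 stands lowest of the two; compound 2, its only neighbour, sits at a markedly higher value, and that gap lies beyond the scatter. For the measured compounds named here, no pair of measured compounds differs in just one place, so nothing yet shows how a single change moves this read-out.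

Compound 3, `CC(C)(C)OC(=O)CCCCC[N+]1(C)CCc2c(sc(NC(=O)Nc3ccc(Cl)cc3)c2C(N)=O)C1`, differs from compound 1 in one place: 2-(tert-butoxycarbonyl)ethyl in place of tert-butoxycarbonyl on a saturated chain carbon, three bonds along the chain from an amine nitrogen in a ring. The chain ending in the tert-butoxycarbonyl group is lengthened while the rest of compound 1 is kept. Going by the values given here, with no comparable step known, only a small movement is expected, none beyond the scatter, in either direction. For compound 3 the estimate is 300 nM, with a range from 100 nM to 1000 nM, which means an expected step of a 1.2-fold higher number from compound 1 to compound 3 (0.08 log units; within the scatter) that stays within the scatter.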

Compound 3, half-maximal effective concentration: 110 nM
Compound 3: the middle estimate sits 2.7-fold (0.44 log units) above what was measured; the measured number falls inside the stated range.
By their numbers in this assay, from the lowest: compound 3; then compound 1; then compound 2.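

Among the compounds shown here, compound 1 and compound 3 are the first pair that differ in one place, so the read-out in this assay can now be followed through a single change. Putting 2-(tert-butoxycarbonyl)ethyl in place of tert-butoxycarbonyl, on a saturated chain carbon, three bonds along the chain from an amine nitrogen in a ring, gives a 2.3-fold lower number from compound 1 to compound 3 (0.36 log units; beyond the scatter), a modest step, which shows that this position tolerates a longer chain and that chain length alone can move the number. No measurement here explains this shift.

As far as these compounds go, whether a still longer chain would continue this trend remains open, since one step cannot show a trend. Also open, from the compounds shown here alone, is how a carboxylic acid, or an amine, at the end of the chain would compare with the tert-butoxycarbonyl group.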